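Amide Swap to Hydroxymethylethyl on a Shared Pyrrole Core

The source may report more compounds than this note shows. Statements on the series, on what has been measured and on what is new or still open speak of the compounds shown alone.

Compound 1 `CCOc1ccc(NC(=O)c2ccc(C(CC)(CC)c3ccc(OCCC(O)(CC)CC)c(C)c3)n2CC)cc1` in a functional assay on Caco-2 cells (Homo sapiens) for antiproliferative activity, read by MTT assay, with a stated time of 48 h (a higher number here means a weaker inhibitor, a lower number a stronger inhibitor), gives > 50000 nM, a limit of the assay.
Compound 2 `CCC(C)C(NC(=O)c1ccc(C(CC)(CC)c2ccc(OCCC(O)(CC)CC)c(C)c2)n1CC)C(=O)OC` in this assay gives > 50000 nM, also a limit of the assay.

Compound 2 thus stands only at a limit, not at a number, and the limit of > 50000 nM in this assay, at which 2 of the 2 values shown sit, applies to both values shown. The step that the two limits leave unreadable from compound 1 to compound 2 cannot be read for size. Compound 3 `CCn1c(C(=O)NC(C)CO)ccc1C(CC)(CC)c1ccc(OCCC(O)(CC)CC)c(C)c1` differs from compound 2 by a group of 4 heavy atoms (3 carbon, 1 oxygen; no ring) in place of a group of 9 heavy atoms (7 carbon, 2 oxygen; no ring), on an amide-type nitrogen. Going by the values given here, no measured step reads out, so no direction can be drawn from the data. Compound 3 is therefore expected to return a limit again, with the step that the limit leaves unreadable from compound 2 to compound 3 unreadable, giving an estimate of 80000 nM within 30000 nM to 300000 nM.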

Compound 3, half-maximal inhibitory concentration: > 50000 nM
Compound 3: a limit, no number; the forecaster's own chance of this, stated with the estimate: 85%; the middle value does not contradict the limit.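

No step among compound 1, compound 2 and compound 3 can be read, since all three rest at the same limit: the limit of > 50000 nM in this assay, at which 3 of the 3 values shown sit.

As far as these compounds go, whether any group on the amide-type nitrogen of this shared core gives a measurable value in this assay stays open.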